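This account rests on a few compounds, and the source may have more. Where it says the series, first, only, none or still open, it means among the compounds named here.

Within the data shown here, compound 1 `CCNCc1ccc(Cl)c(-c2ccccc2OC)c1` stands at the weaker end of the two compounds so far measured in an assay on isolated protein for binding affinity to 5-hydroxytryptamine receptor 5A (Homo sapiens); a lower number here means a stronger inhibitor, a higher number a weaker inhibitor: compound 1 gives 1800 nM, the highest of the two numbers. Compound 2 `CCCCNCc1ccc(Cl)c(-c2ccccc2OC)c1` differs from it only at the saturated chain carbon two bonds along the chain from the amine nitrogen, and compound 2 gives 360 nM, a step of a 5.0-fold lower number from compound 1 to compound 2 (0.70 log units; beyond the scatter). Compound 3 `CCCNCc1ccc(Cl)c(-c2ccccc2OC)c1` carries a smaller version of that same change: methyl in place of hydrogen on a saturated chain carbon, two bonds along the chain from an amine nitrogen. Because the larger addition produced a 5.0-fold lower number from compound 1 to compound 2 (0.70 log units; beyond the scatter), a smaller improvement in the same direction is expected, about a 2.3-fold lower number from compound 1 to compound 3 (0.35 log units; beyond the scatter). Compound 3 is therefore estimated at 800 nM, likely between 400 nM and 1600 nM.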

Compound 3, inhibition constant: 120 nM
Compound 3: the middle estimate sits 6.7-fold (0.82 log units) above what was measured, outside the stated range (below it).
By their numbers in this assay, from the lowest: compound 3; then compound 2; then compound 1.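

The gain from lengthening the chain is not steady: methyl in place of hydrogen, taking ethylamino to propylamino, gives a 15-fold lower number from compound 1 to compound 3 (1.18 log units; beyond the scatter) and exceeds what the longer chain of compound 2 achieves. Hydrogen in place of the outer methyl gives a 3.0-fold lower number from compound 2 to compound 3 (0.48 log units; beyond the scatter) and shows that, among these three compounds, the added carbon at that outer place gives back part of the gain. Nothing available bears on the reason for this. Going by these compounds, how a branched isopropyl group, a cyclopropylmethyl group or a longer pentyl chain on the amine nitrogen would compare with the propyl chain stays open.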